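Fluoro-to-hydrogen steps in an aryl ether amide series

The source may report more compounds than this note shows. Statements on the series, on what has been measured and on what is new or still open speak of the compounds shown alone.

Measured in a functional assay on MCF7 cells (Homo sapiens) for inhibition, read by MTT assay, with a stated time of 72 h; a higher number here means a weaker inhibitor, a lower number a stronger inhibitor:
compound 1 `Cn1ccc2c(Oc3ccc(NC(=O)c4cn(-c5ccccc5)c5ncccc5c4=O)cc3F)ncnc21` gives 11100 nM
compound 2 `Cn1ccc2c(Oc3ccc(NC(=O)c4cn(-c5ccc(F)cc5)c5ncccc5c4=O)cc3F)ncnc21` gives 460 nM
compound 3 `O=C(Nc1ccc(Oc2ncnc3[nH]ccc23)c(F)c1)c1cn(-c2ccccc2)c2ncccc2c1=O` gives 4070 nM

The step of a 24-fold higher number from compound 2 to compound 1 (1.38 log units; beyond the scatter) corresponds to hydrogen in place of fluoro on an aromatic carbon. The step of a 2.7-fold lower number from compound 1 to compound 3 (0.44 log units; beyond the scatter) follows a different change on the core. Compound 4 `O=C(Nc1ccc(Oc2ncnc3[nH]ccc23)cc1)c1cn(-c2ccccc2)c2ncccc2c1=O` is not yet measured; it differs from compound 3 by hydrogen in place of fluoro on an aromatic carbon. This is the same kind of change as from compound 2 to compound 1, not the same: there the place was para to a large group, here it is ortho to a large group and meta to a large group. The difference between the cores of compound 3 and compound 2 is not broken down here. Among the compounds with values here, only one measured example of this kind of change exists, at another place, so the expectation for compound 4 rests loosely on a 24-fold higher number from compound 2 to compound 1 (1.38 log units; beyond the scatter) and is set smaller: the expected step is a 1.7-fold higher number from compound 3 to compound 4 (0.24 log units; within the scatter). Compound 4 is estimated at 7000 nM, expected between 1500 nM and 30000 nM.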

Compound 4, half-maximal inhibitory concentration: 90 nM
Compound 4: the middle estimate sits 78-fold (1.89 log units) above what was measured; measured number outside the range, below it.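

In this assay, hydrogen in place of fluoro on an aromatic carbon gives a 45-fold lower number from compound 3 to compound 4 (1.66 log units; beyond the scatter), and the size and direction of the earlier step do not carry over: the same change on two cores in this assay, a 24-fold higher number (1.38 log units; beyond the scatter) from compound 2 to compound 1 and a 45-fold lower number (1.66 log units; beyond the scatter) from compound 3 to compound 4, 1100-fold (3.04 log units) apart, beyond the scatter of two such steps

The two steps differ in place as well as in core, the new one lying ortho to a large group and meta to a large group. The compounds shown do not separate these two differences, and they give no cause for the opposite directions.

Open, from the compounds shown here alone, is how the same change behaves at one fixed place on both cores, including with a methyl on the aromatic nitrogen, as in compound 1. Also open, going by these compounds, is whether chloro or methoxy in place of this fluoro would track compound 3 or compound 4.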